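Adding hydroxy to the benzoyl ring of compound 2

This account rests on a few compounds, and the source may have more. Where it says the series, first, only, none or still open, it means among the compounds named here.

For the measured compounds named here, in a functional assay on SK-BR-3 cells (Homo sapiens) for antiproliferative activity (on this read-out higher numbers stand for weaker inhibition and lower numbers for stronger inhibition), compound 2 (`Cc1c(OC2CCN(C)CC2)ccc2cc(NC(=O)c3ccccc3)c(=O)oc12`) gives 11500 nM and stands highest of the two numbers so far, while compound 1 (`CC(=O)Oc1ccc(C(=O)Nc2cc3ccc(OC4CCN(C)CC4)c(C)c3oc2=O)cc1`) gives 1670 nM in the same read-out. Compound 3 (`Cc1c(OC2CCN(C)CC2)ccc2cc(NC(=O)c3ccc(O)cc3)c(=O)oc12`) carries hydroxy in place of hydrogen on an aromatic carbon, para to a large group. Going by the values given here, the one measured step bearing on this is a 6.9-fold higher number from compound 1 to compound 2 (0.84 log units; beyond the scatter) with acetoxy replaced by hydrogen there. Hydroxy is not acetoxy, so a smaller move towards a lower number is expected, estimated as a 3.3-fold lower number from compound 2 to compound 3 (0.52 log units; beyond the scatter) in size. Compound 3 is expected at 3500 nM, with a range from 1200 nM to 10000 nM around that estimate.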

Compound 3, half-maximal inhibitory concentration: 840 nM
Compound 3: middle estimate off by 4.2-fold (0.62 log units), on the high side; measured number outside the range, below it.
By their numbers in this assay, from the lowest: compounds 3 and 1 (each within the scatter of the next); then compound 2.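

On the phenyl to 4-hydroxyphenyl change in this assay, the hydroxy alone accounts for a large step (a 14-fold lower number from compound 2 to compound 3 (1.14 log units; beyond the scatter)), showing that this position, para to a large group, responds to a free hydroxy and not only to acetoxy. Removing the acetyl from that oxygen leaves a difference that stays within the scatter (a 2.0-fold lower number from compound 1 to compound 3 (0.30 log units; within the scatter)), so compound 1 and compound 3 cannot be told apart here. Nothing available explains why this oxygen-bearing substitution matters. As far as these compounds go, it remains open whether a methoxy group, an amine or a fluorine at this place would match the hydroxy.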